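A chloro added to a compound at the assay limit

The compounds below may be only part of what the source reports. "The series", "measured", "known", "first", "only" and "open" are said of these compounds alone.

- Compound 1 `CCCCOc1cccc(-c2[nH]c3cc(OC)ccc3c(=O)c2C(=O)OCC)c1`: > 22000 nM, a limit
- Compound 2 `CCOC(=O)c1c(-c2cccc(OC(F)(F)F)c2)[nH]c2cc(OC)ccc2c1=O`: > 22000 nM, a limit
- Compound 3 `CCOC(=O)c1c(-c2cccc(Cl)c2)[nH]c2cc(OC)ccc2c1=O`: > 22000 nM, a limit

These results come from an ADME assay on HEK293 cells (Homo sapiens) for cytotoxicity, read by luminescence, with a stated time of 72 h; a higher number here means that more compound is needed for the effect, a lower number that less compound is needed. Compound 3 has only a limit, > 22000 nM, and no exact number. Compound 4 `CCOC(=O)c1c(-c2cccc(Cl)c2)[nH]c2cc(OC)c(Cl)cc2c1=O` differs from compound 3 by chloro in place of hydrogen on an aromatic carbon, which is chloro in place of hydrogen on an aromatic carbon, ortho to a methoxy group. The measured steps are only a loose guide, since each swaps a group at a different place: a step that the two limits leave unreadable from compound 1 to compound 2, a step that the two limits leave unreadable from compound 1 to compound 3 and a step that the two limits leave unreadable from compound 2 to compound 3. Because of the limit of > 22000 nM in this assay, at which 3 of the 3 values shown sit, no step beyond the scatter is expected for compound 4 in this assay. The expected size is a number no higher from compound 3 to compound 4 (the limit leaves the size open). Compound 4 is estimated at 22000 nM, with an expected range from 11000 nM to 30000 nM.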

Compound 4, half-maximal effective concentration: > 22000 nM
Compound 4 was reported as a limit (the forecaster's own chance of this, stated with the estimate: 80%); the middle value sits exactly at the limit.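

No step can be read from compound 3 to compound 4 in this assay, since neither has an exact number: the limit of > 22000 nM in this assay, at which 4 of the 4 values shown sit.

The compounds shown leave open whether the added chloro changes the concentration needed for the effect.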